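The compounds below may be only part of what the source reports. "The series", "measured", "known", "first", "only" and "open" are said of these compounds alone.

Compound 1 `C=CCCn1c(=O)c2[nH]cnc2n(CCC)c1=O`: in a functional assay (trachea) with Cavia porcellus as the target (a lower number here means that less compound is needed, a higher number that more compound is needed for the effect), compound 1 gives 200 nM.
Compound 2 `CCCn1c(=O)n(CCC(=O)O)c(=O)c2[nH]cnc21`: in this assay compound 2 gives 21200 nM.
Compound 3 `CCCn1c(=O)n(CCO)c(=O)c2[nH]cnc21`: in this assay compound 3 gives 510 nM.

Compound 2 has the highest number of the three, set well apart in this assay by a 42-fold lower number from compound 2 to compound 3 (1.62 log units; beyond the scatter) and by a 110-fold higher number from compound 1 to compound 2 (2.03 log units; beyond the scatter). Compound 4 `CCCn1c(=O)n(CCOC)c(=O)c2[nH]cnc21` differs from compound 2 in one place: methoxy in place of carboxy on a saturated chain carbon, two bonds along the chain from an aromatic nitrogen. The step that bears most directly on this is a 42-fold lower number from compound 2 to compound 3 (1.62 log units; beyond the scatter), where the carboxy also leaves and a small oxygen-bearing group enters at the same place; a 110-fold higher number from compound 1 to compound 2 (2.03 log units; beyond the scatter) points the same way. A large fall in the number is therefore expected when the carboxy leaves, with compound 4 expected to land near compound 3. Compound 4 is estimated at 400 nM, within 150 nM to 1500 nM, which means an expected step of a 53-fold lower number from compound 2 to compound 4 (1.72 log units; beyond the scatter).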

Compound 4, half-maximal effective concentration: 700 nM
Compound 4: middle estimate off by 1.8-fold (0.24 log units), on the low side; low and high end bracket the measured number.
By their numbers in this assay, from the lowest: compound 1; then compounds 3 and 4 (each within the scatter of the next); then compound 2.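

The 2-methoxyethyl chain removes nearly all of the penalty seen with the 2-carboxyethyl chain (a 30-fold lower number from compound 2 to compound 4 (1.48 log units; beyond the scatter)), so the low number does not require a free hydroxy at this position. Methyl in place of the hydrogen on that oxygen makes no difference beyond the scatter in this assay (a 1.4-fold higher number from compound 3 to compound 4 (0.14 log units; within the scatter)). The chain carrying vinyl still gives the lower number (a 3.5-fold higher number from compound 1 to compound 4 (0.54 log units; beyond the scatter)).

Nothing measured here explains why these groups give these numbers. As far as these compounds go, how an amine or a longer ether chain at this place would behave remains open.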